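Fluorine shift and shorter chain: what happens next?

The compounds below may be only part of what the source reports. "The series", "measured", "known", "first", "only" and "open" are said of these compounds alone.

- Compound 1 `CN1CCCN(CCNc2nccc(-c3c(-c4cccc(O)c4)nc4sccn34)n2)S1(=O)=O` gives 11600 nM
- Compound 2 `O=S(=O)(NCCCNc1nccc(-c2c(-c3cccc(O)c3)nc3sccn23)n1)c1cccc(F)c1` gives 2380 nM

In a functional assay on cells (Panel prostate (Carcinoma cell lines), Homo sapiens) for inhibition, read by sulforhodamine B assay, with a stated time of 48 h (on this read-out lower numbers stand for stronger inhibition and higher numbers for weaker inhibition), compound 2 has the lower of the two numbers, at 2380 nM so far. Compound 3 `O=S(=O)(NCCNc1nccc(-c2c(-c3cccc(O)c3)nc3sccn23)n1)c1ccc(F)cc1` brings this change: ((4-fluorophenyl)sulfonyl)amino in place of (((3-fluorophenyl)sulfonyl)amino)methyl on a saturated chain carbon, two bonds along the chain from a nitrogen on an aromatic ring so ((4-fluorophenyl)sulfonyl)amino replaces (((3-fluorophenyl)sulfonyl)amino)methyl. Within the data shown here, only one measured step bears on this, a 4.9-fold lower number from compound 1 to compound 2 (0.69 log units; beyond the scatter) and it swapped a ring of a different kind. Here both groups hold a six-membered aromatic ring of carbon only, so a smaller step is expected, with no direction favoured. The expected result is a 1.1-fold higher number from compound 2 to compound 3 (0.02 log units; within the scatter) in this assay as an estimate. For compound 3 the estimated value is 2500 nM with an expected range from 900 nM to 7000 nM overall.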

Compound 3, half-maximal inhibitory concentration: 7300 nM
Compound 3: the middle estimate sits 2.9-fold (0.47 log units) below what was measured; measured number outside the range, above it.
By their numbers in this assay, from the lowest: compound 2; then compounds 3 and 1 (each within the scatter of the next).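

In this assay, this position responds even when both groups hold a six-membered aromatic ring of carbon only: a 3.1-fold higher number from compound 2 to compound 3 (0.49 log units; beyond the scatter). An aromatic ring in the group is therefore not enough on its own: a 1.6-fold lower number from compound 1 to compound 3 (0.20 log units; within the scatter). No measurement shown here explains these results.

This step both removes the methyl link and moves the fluorine from the 3 to the 4 position, so the two changes cannot be separated. An (((4-fluorophenyl)sulfonyl)amino)methyl group would keep the link with the fluorine at 4, which would help tell them apart.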